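The compounds below may be only part of what the source reports. "The series", "measured", "known", "first", "only" and "open" are said of these compounds alone.

Working notes on the series:

- Compound 1 `O=C(NNc1ccccc1Cl)c1cccc(NS(=O)(=O)c2cnc(O)nc2O)c1`: 2090 nM
- Compound 2 `O=C(NNC(=O)c1ccc(NS(=O)(=O)c2cnc(O)nc2O)cc1)c1ccc(F)cc1`: > 20000 nM
- Compound 3 `O=C(NNC(=O)c1cccc(NS(=O)(=O)c2cnc(O)nc2O)c1)c1cccc(Cl)c1`: not yet measured

Going by the values given here, in a functional assay on MDA-MB-231 cells (Homo sapiens) for antiproliferative activity, read by MTT assay, with a stated time of 24 h (a lower number here means a stronger inhibitor, a higher number a weaker inhibitor), compound 1 gives 2090 nM, the only actual number so far. Compound 2 gives > 20000 nM, which is a limit of the assay and not a number.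

Compound 3 carries (3-chlorophenyl)carbonyl in place of 2-chlorophenyl on an amine nitrogen. Among the compounds with values here, no step between measured compounds exists to size this change, so the expectation is loose. It leans towards weaker inhibition in this assay, beyond the usual scatter. Within the data shown here, that lean rests on compound 2, whose > 20000 nM is the only other reading. The expected step is a 3.3-fold higher number from compound 1 to compound 3 (0.52 log units; beyond the scatter). For compound 3 the estimated value is 7000 nM, with an expected range of 2000 nM to 20000 nM.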

Compound 3, half-maximal inhibitory concentration: 3180 nM
Compound 3: the middle estimate sits 2.2-fold (0.34 log units) above what was measured; the range from low to high includes it.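

The replacement of 2-chlorophenyl by (3-chlorophenyl)carbonyl on an amine nitrogen whose other neighbour is an amide-type nitrogen gives, in this assay, a 1.5-fold higher number from compound 1 to compound 3 (0.18 log units; within the scatter). This position therefore accepts the change, with its added carbonyl, without a reading that can be told apart from compound 1. Compound 2 remains a limit and not a number, so no step to it can be read, and its reading gives no cause for the result at this position: the limit of > 20000 nM in this assay, at which 1 of the 3 values shown sits.

The step carries the added carbonyl and the different chlorophenyl substitution as one change, so their separate contributions remain unresolved. Also open, on these data alone, is how a carboxylic acid or an amine in place of the chlorine of compound 3 would read in this assay.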